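Dichloro for Dimethyl on the Ring Nitrogen Arm

The source may hold more compounds than are shown below. What is called first, only, known or untested is meant among the compounds shown, and "the series" means these compounds.

For the measured compounds named here, compound 2 `Cc1cccc(N2CCN(CCCNc3nc(NCc4ccco4)c4ccccc4n3)CC2)c1C` gives the lowest number among the three compounds measured so far. In a functional assay on DU-145 cells (Homo sapiens) for cytotoxicity, read by MTT assay, with a stated time of 2 days (on this read-out lower numbers stand for stronger inhibition and higher numbers for weaker inhibition), compound 2 gives 930 nM. Compound 1 `CCCCNc1nc(NCc2ccco2)c2ccccc2n1`, the smallest of the three, gives 4990 nM in this assay, and compound 3 `Cc1cccc(N2CCN(CCCNc3nc(NCc4ccco4)c4cc(F)ccc4n3)CC2)c1C` gives 2660 nM. Going by the values given here, the one single-point step measured, a 2.9-fold higher number from compound 2 to compound 3 (0.46 log units; beyond the scatter), concerns a fluoro on the shared core and leaves the rest of the molecule untouched.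

Compound 4 `Clc1cccc(N2CCN(CCCNc3nc(NCc4ccco4)c4ccccc4n3)CC2)c1Cl` differs from compound 2 by 2,3-dichlorophenyl in place of 2,3-dimethylphenyl on an amine nitrogen in a ring, three ring bonds from the ring nitrogen. Among the compounds with values here, no measured step concerns this part of the molecule; the values of compound 1 and compound 2 show only that the longer portion of compound 2 matters, not what its aryl substituents do. The step expected here is therefore small, a 1.2-fold higher number from compound 2 to compound 4 (0.07 log units; within the scatter), and within the scatter of this assay. Compound 4 is expected to give 1100 nM in this assay, with a range from 400 nM to 3000 nM.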

Compound 4, half-maximal inhibitory concentration: 3710 nM
Beside the measured number, compound 4's estimate is 3.4-fold (0.53 log units) below it; measured number outside the range, above it.
By their numbers in this assay, from the lowest: compound 2; then compounds 3, 4 and 1 (each within the scatter of the next).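

In this assay, the aryl group on the amine nitrogen in the ring proves to matter: the step is a 4.0-fold higher number from compound 2 to compound 4 (0.60 log units; beyond the scatter), although the exchange keeps 8 heavy atoms, one six-membered aromatic ring of carbon only, and 0 hydrogen-bond donors and acceptors in the group. For the compounds shown here, until now, the only single-place step was a 2.9-fold higher number from compound 2 to compound 3 (0.46 log units; beyond the scatter) on the shared core, so this result adds a second part of the molecule where a change from compound 2 gives a higher number, and both steps lie beyond the scatter. No measurement given here bears on what lies behind the difference between 2,3-dichlorophenyl and 2,3-dimethylphenyl.

The compounds shown leave open whether this step follows from the presence of chlorine or from the loss of methyl, a question that a plain phenyl, a 2-chlorophenyl or a 2-methoxyphenyl on the same nitrogen could help to settle. They also leave open whether the same exchange would give a step of similar size on the fluoro core of compound 3.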